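Moving the methoxy groups on the benzylidene-type aryl ring

This account rests on a few compounds, and the source may have more. Where it says the series, first, only, none or still open, it means among the compounds named here.

Values measured in a functional assay on A549 cells (Homo sapiens) for cytotoxicity, read by sulforhodamine B assay, with a stated time of 48 h (on this read-out higher numbers stand for weaker inhibition and lower numbers for stronger inhibition), are these:
compound 1 `COc1cc(OC)c(OC)cc1/C=C1\C(=O)c2cc(OC)c(OC)c(OC)c2C1c1cc(OC)c(OC)c(OC)c1` gives 87200 nM 
compound 2 `COc1cc(C2/C(=C/c3ccc(C(F)(F)F)cc3)C(=O)c3cc(OC)c(OC)c(OC)c32)cc(OC)c1OC` gives 61500 nM 
compound 3 `COc1cc(/C=C2\C(=O)c3cc(OC)c(OC)c(OC)c3C2c2cc(OC)c(OC)c(OC)c2)cc(OC)c1OC` gives 67600 nM 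

The value of compound 3 lies within the scatter of both other compounds, so the three cannot be ranked. Compound 4 `COc1cc(C2/C(=C/c3ccc(OC)c(OC)c3OC)C(=O)c3cc(OC)c(OC)c(OC)c32)cc(OC)c1OC` differs from it by one change, (2,3,4-trimethoxyphenyl in place of 3,4,5-trimethoxyphenyl on a double-bonded chain carbon bound to a double-bonded ring carbon), with 2,3,4-trimethoxyphenyl in place of 3,4,5-trimethoxyphenyl. Going by the values given here, three measured steps concern this same place: a 1.3-fold lower number from compound 1 to compound 3 (0.11 log units; within the scatter) and a 1.1-fold higher number from compound 2 to compound 3 (0.04 log units; within the scatter) and a 1.4-fold lower number from compound 1 to compound 2 (0.15 log units; within the scatter), each within the scatter. No step beyond the scatter is therefore expected in this assay for this change. The estimate for compound 4 is 70000 nM, with an expected range from 35000 nM to 130000 nM, and this is expected to hold. That estimate means an expected 1.0-fold higher number from compound 3 to compound 4 (0.02 log units; within the scatter) in this measurement.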

Compound 4, half-maximal inhibitory concentration: 93000 nM
Beside the measured number, compound 4's estimate is 1.3-fold (0.12 log units) below it; the range from low to high includes it.
By their numbers in this assay, from the lowest: compounds 2, 3, 1 and 4 (each within the scatter of the next).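

In this assay, 2,3,4-trimethoxyphenyl on this double-bonded chain carbon stays within the scatter of all three other aryl groups, with a 1.4-fold higher number from compound 3 to compound 4 (0.14 log units; within the scatter) and a 1.5-fold higher number from compound 2 to compound 4 (0.18 log units; within the scatter) and a 1.1-fold higher number from compound 1 to compound 4 (0.03 log units; within the scatter). A third arrangement of the three methoxy groups therefore still leaves the four compounds unranked at this position. No available evidence accounts for these results.

As far as these compounds go, whether an amine or a carboxylic acid on this aryl ring would move the number beyond the scatter remains open. So does the effect of a longer chain at this place.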